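The source may hold more compounds than are shown below. What is called first, only, known or untested is meant among the compounds shown, and "the series" means these compounds.

Of the compounds shown here, three with a shared core have been tested in an assay on HEK293 cells for displacement of a labelled ligand from Type-2 angiotensin II receptor (Homo sapiens), read by scintillation counting, with a stated time of 240 min; a lower number here means a stronger inhibitor, a higher number a weaker inhibitor. Compound 1 `CCOC(=O)NS(=O)(=O)c1sc(CC(C)C)cc1-c1cccc(Cn2ccnc2)c1` gives 300 nM, compound 2 `CCC(C)OC(=O)NS(=O)(=O)c1sc(CC(C)C)cc1-c1cccc(Cn2ccnc2)c1` gives 440 nM, and compound 3 `CC(C)COC(=O)NS(=O)(=O)c1sc(CC(C)C)cc1-c1cccc(Cn2ccnc2)c1` gives 130 nM, the lowest of the three numbers, since a 2.3-fold lower number from compound 1 to compound 3 (0.36 log units; beyond the scatter) and a 3.4-fold lower number from compound 2 to compound 3 (0.53 log units; beyond the scatter). Compound 4 `CC(C)CCOC(=O)NS(=O)(=O)c1sc(CC(C)C)cc1-c1cccc(Cn2ccnc2)c1` carries isobutyl in place of isopropyl on a saturated chain carbon bound to an oxygen next to a carbonyl group, so the chain on the ester oxygen is extended once more. Among the measured compounds shown here, two measured steps bear on this: a 2.3-fold lower number from compound 1 to compound 3 (0.36 log units; beyond the scatter), where the same carbon was enlarged, while a 1.5-fold higher number from compound 1 to compound 2 (0.17 log units; within the scatter). Taken together, the step from compound 3 to compound 4 is expected to be small, most likely within the scatter, estimated as a 1.2-fold lower number from compound 3 to compound 4 (0.07 log units; within the scatter). Compound 4 is therefore expected near 110 nM, within a range from 45 nM to 300 nM.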

Compound 4, inhibition constant: 230 nM
Compound 4: the middle estimate sits 2.1-fold (0.32 log units) below what was measured; low and high end bracket the measured number.
By their numbers in this assay, from the lowest: compounds 3, 4, 1 and 2 (each within the scatter of the next, the first and the last beyond it).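

Extending the chain on the oxygen once more, from isobutyl to isopentyl, gives a 1.8-fold higher number from compound 3 to compound 4 (0.25 log units; within the scatter) in this assay, so the gain from the earlier enlargement does not clearly continue. The isopentyl chain also cannot be separated from the sec-butyl chain, with a 1.9-fold lower number from compound 2 to compound 4 (0.28 log units; within the scatter), or from the ethyl chain, with a 1.3-fold lower number from compound 1 to compound 4 (0.12 log units; within the scatter). No measured evidence here accounts for these results. Going by these compounds, whether a longer chain, a phenyl ring or an amine at this position would move the number remains open.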